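Piperazin-1-yl in Place of Benzylamino: An Expected Outcome

The source may hold more compounds than are shown below. What is called first, only, known or untested is meant among the compounds shown, and "the series" means these compounds.

Of the compounds shown here, three have so far been tested in a functional assay on MDA-MB-435 cells (Homo sapiens) for cytotoxicity, read by MTT assay, with a stated time of 72 h; on this read-out lower numbers stand for stronger inhibition and higher numbers for weaker inhibition. Compound 1 `O=C(NCc1ccc(F)cc1)c1nc(Br)c2cccnc2c1NCCCNc1c(C(=O)NCc2ccc(F)cc2)nc(Br)c2cccnc12` returns only a limit of the assay, > 20000 nM. Compound 2 `O=C(NCc1ccc(F)cc1)c1nc(Br)c2cccnc2c1NCc1ccccc1` likewise returns a limit in this assay, namely > 20000 nM. Among the compounds with values here, compound 3 `CS(=O)(=O)NCCCCCCN(c1nc(C(=O)NCc2ccc(F)cc2)c(O)c2ncccc12)S(C)(=O)=O` is the one compound with a number rather than a limit, and in this assay it gives compound 3 a value of 20000 nM. Within the data shown here, compound 2 therefore stands at the edge of what the assay can report, and the whole set is summed up by the limit of > 20000 nM in this assay, at which 2 of the 3 values shown sit: no measured compound shows an effect that the assay resolves as a clear number well inside its range.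

Compound 4 `O=C(NCc1ccc(F)cc1)c1nc(Br)c2cccnc2c1N1CCNCC1` differs from compound 2 in a single place, (piperazin-1-yl in place of benzylamino on an aromatic carbon). No measured pair of this kind exists among the three compounds, so the size of the step cannot be read from the numbers shown. With every measured compound sitting at or near the top of the range, compound 4 is expected to remain in that region, and the step of a number no higher from compound 2 to compound 4 (the limit leaves the size open) is expected to be none beyond the scatter. Compound 4 is accordingly estimated at 20000 nM in this assay, within 6000 nM to 40000 nM.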

Compound 4, half-maximal inhibitory concentration: 8000 nM
The estimate for compound 4 lay 2.5-fold (0.40 log units) above the measured number; the measured number falls inside the stated range.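

The exchange gives an at least 2.5-fold lower number from compound 2 to compound 4 (0.39 log units; beyond the scatter) in this assay, so the group on this aromatic carbon, para to a bromo group, does change the read-out on the shared core. Compound 2 and compound 4 differ only here: the benzylamino group with its aromatic ring of carbon only gives way to piperazin-1-yl, a non-aromatic ring with 2 hetero atoms. The true size of the step stays unknown because it starts from a limit of the assay rather than a number: the limit of > 20000 nM in this assay, at which 2 of the 4 values shown sit.

The compounds shown leave open whether the change depends on the second ring nitrogen of piperazin-1-yl, which piperidin-1-yl or morpholin-4-yl at the same place could test. They also leave open how a methyl group on that ring nitrogen would affect the read-out.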